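Second Hydroxyl on the Seven-Membered Ring of Compound 2

This account rests on a few compounds, and the source may have more. Where it says the series, first, only, none or still open, it means among the compounds named here.

Of the compounds shown here, three have so far been measured in a functional assay on Col2 cells (Homo sapiens) for cytotoxicity; a higher number here means that more compound is needed for the effect, a lower number that less compound is needed. Compound 1 `C=C[C@@](C)(O)C[C@@H](O)/C=C(\C)CC/C=C(\C)COC(C)=O` gives 6.2 ug/mL, compound 2 `C=C1C(=O)O[C@@H]2[C@@H]1CC[C@H](C)[C@@](O)(C(=O)/C=C/C)[C@H]2OC(=O)/C(C)=C\C` gives 0.9 ug/mL, and compound 3 `C=C1C(=O)O[C@@H]2[C@@H]1C[C@@H](O)[C@H](C)[C@@](O)(C(=O)/C=C/C)[C@H]2OC(=O)/C(C)=C\C` gives 0.5 ug/mL. Among these three numbers compound 2 stands second highest: its nearest neighbour is compound 3, reached by a step that is a 1.8-fold lower number from compound 2 to compound 3 (0.26 log units; within the scatter), while compound 1 lies farthest away, with a number that is higher by a margin beyond the scatter.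

Compound 4 `C=C1C(=O)O[C@@H]2[C@@H]1[C@@H](O)C[C@H](C)[C@@](O)(C(=O)/C=C/C)[C@H]2OC(=O)/C(C)=C\C` differs from compound 2 in one place: hydroxy in place of hydrogen on a saturated ring carbon. Within the data shown here, only one measured step bears on this change, the one in which a hydroxy likewise replaced hydrogen on a saturated ring carbon of the same seven-membered ring, at another position; that step was a 1.8-fold lower number from compound 2 to compound 3 (0.26 log units; within the scatter). Because that step was a 1.8-fold lower number from compound 2 to compound 3 (0.26 log units; within the scatter), compound 4 is expected to remain close to compound 2, with any movement most likely toward a lower number and not beyond the scatter. The step that this expectation implies, from compound 2 onward, is expected to be a 1.3-fold lower number from compound 2 to compound 4 (0.11 log units; within the scatter). For compound 4 the estimate in this assay is 0.7 ug/mL, within a range from 0.3 ug/mL to 1.8 ug/mL.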

Compound 4, concentration for half-maximal effect: 5.7 ug/mL
Compound 4: the middle estimate sits 8.1-fold (0.91 log units) below what was measured, and the stated range ends below it.
By their numbers in this assay, from the lowest: compounds 3 and 2 (each within the scatter of the next); then compounds 4 and 1 (each within the scatter of the next).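

In this assay the hydroxy in place of hydrogen on this saturated ring carbon, next to the ring atom that bears a fused ring, produces a 6.3-fold higher number from compound 2 to compound 4 (0.80 log units; beyond the scatter) and thus shows that the seven-membered ring does not accept this change everywhere without consequence. The same exchange at another carbon of that ring gave a 1.8-fold lower number from compound 2 to compound 3 (0.26 log units; within the scatter) and stayed within the scatter, so among these compounds the outcome depends on where the hydroxy stands and not merely on its presence on the ring. Nothing available here explains why this position behaves differently from the other one.

The compounds shown leave open whether the higher number belongs to the hydroxy itself or would also appear with a methoxy group, an acetate ester or an amine on the same carbon. They also leave open whether a hydroxy of the opposite orientation at this carbon would give a number closer to that of compound 2, which would separate the effect of the position from that of the spatial arrangement.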